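A few compounds are considered here, and "the series" means these few. Any claim that something is new, unique, unknown or untested is made for them only; others in the source may bear on it.

The measured compounds so far:
- compound 1, `CC(C)=CCC/C(C)=C/CC/C(C)=C/CC[C@@H]1[C@@]2(C)CC/C(=N\OCc3cn(-c4ccc(Cl)cc4)nn3)C(C)(C)[C@@H]2CC[C@@]1(C)O`: 12300 nM
- compound 2, `CC(C)=CCC/C(C)=C/CC/C(C)=C/CC[C@@H]1[C@@]2(C)CC/C(=N\OCc3cn(-c4cccc(Br)c4)nn3)C(C)(C)[C@@H]2CC[C@@]1(C)O`: 11700 nM
- compound 3, `CC(C)=CCC/C(C)=C/CC/C(C)=C/CC[C@@H]1[C@@]2(C)C/C(=C\c3ccc(OCc4cn(-c5ccc(Cl)cc5)nn4)cc3)C(=O)C(C)(C)[C@@H]2CC[C@@]1(C)O`: 83200 nM

All three were tested in a functional assay on A549 cells (Homo sapiens) for cytotoxicity, read by MTT assay, with a stated time of 48 h; a lower number here means a stronger inhibitor, a higher number a weaker inhibitor. Compound 1 and compound 2 share one core and differ only at the triazole nitrogen, where (3-bromophenyl in place of 4-chlorophenyl on an aromatic nitrogen). This change made a 1.1-fold lower number from compound 1 to compound 2 (0.02 log units; within the scatter), so the two numbers cannot be told apart. Compound 3 sits on a different core; how its core differs from that of compound 1 is not broken down here, but in this assay compound 3 gives a number far higher than either compound 1 or compound 2.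

Compound 4, `CC(C)=CCC/C(C)=C/CC/C(C)=C/CC[C@@H]1[C@@]2(C)C/C(=C\c3ccc(OCc4cn(-c5cccc(Br)c5)nn4)cc3)C(=O)C(C)(C)[C@@H]2CC[C@@]1(C)O`, is the unmeasured partner of compound 3: 3-bromophenyl in place of 4-chlorophenyl on an aromatic nitrogen. The place of the change is the same as between compound 1 and compound 2, so this is the same change on a different core. Because the earlier step was a 1.1-fold lower number from compound 1 to compound 2 (0.02 log units; within the scatter), the step from compound 3 to compound 4 is expected to be small as well, a 1.0-fold lower number from compound 3 to compound 4 (0.02 log units; within the scatter). Compound 4 is therefore estimated at 80000 nM in this assay, within a range of 40000 nM to 160000 nM.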

Compound 4, half-maximal inhibitory concentration: 33800 nM
Compound 4: the middle estimate sits 2.4-fold (0.37 log units) above what was measured; measured number below the stated range.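

On the core of compound 3, replacing 4-chlorophenyl with 3-bromophenyl on the aromatic nitrogen gave a 2.5-fold lower number from compound 3 to compound 4 (0.39 log units; beyond the scatter) in this assay, a modest step. Set beside the same replacement on the core of compound 1, the two steps cannot be told apart: the same change on two cores in this assay, a 1.1-fold lower number (0.02 log units; within the scatter) from compound 1 to compound 2 and a 2.5-fold lower number (0.39 log units; beyond the scatter) from compound 3 to compound 4, 2.3-fold (0.37 log units) apart, within the scatter of two such steps This shows no measurable dependence of the replacement on the core across these two pairs, but two pairs are too few to show that it would carry over in the same way to other cores in the series, and they do not explain why only the step on the core of compound 3 lies beyond the scatter.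

The replacement alters the halogen and its place on the phenyl ring at once, and separating those two changes would take partners carrying 3-chlorophenyl or 4-bromophenyl. The compounds shown also leave open how a very different group on that phenyl ring, such as an amine or a carboxylic acid, would behave on either core.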